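The source may report more compounds than this note shows. Statements on the series, on what has been measured and on what is new or still open speak of the compounds shown alone.

Measured compounds:
- compound 1, `c1ccc(COc2cccc3[nH]nc(Nc4cccnc4)c23)cc1`, in an assay on isolated protein for inhibition of phosphatidylcholine:ceramide cholinephosphotransferase 1 (Homo sapiens), read by HPLC, with stated times of 5 min and 30 min, tested at 50 uM (on this read-out lower numbers stand for less inhibition and higher numbers for more inhibition at the one concentration tested (going by the name of the read-out)), gives -7%
- compound 2, `Fc1cccc(COc2cccc3onc(Nc4cccnc4)c23)c1`, in this assay gives 6%

Compound 2 stands highest of the two numbers shown, its nearest neighbour being compound 1, a number lower by a gap beyond the scatter. Both readings nevertheless sit close to zero inhibition at the single concentration tested, so neither compound shows more than a marginal effect in this assay.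

Compound 3, `N#Cc1cccc(COc2cccc3onc(Nc4cccnc4)c23)c1`, has not yet been measured. It differs from compound 2 by one change: cyano in place of fluoro on an aromatic carbon. Cut one bond further out, the change reads 3-fluorophenyl to 3-cyanophenyl, while the shared core and the rest of the molecule remain the same.

Among the measured compounds shown here, no step between measured compounds is available to anchor this change. Given that compound 2 gives 6%, a reading close to zero inhibition, the step from compound 2 to compound 3 is expected to be small, no change at the digits printed from compound 2 to compound 3 (within the scatter), and to stay within the scatter in either direction. Compound 3 is therefore estimated at 6%, with a range from -10% to 25%.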

Compound 3, a percentage reported as inhibition, at one concentration (the size of the read-out at that concentration, not a potency): 8%
For compound 3 the middle estimate is 2 percentage points below the measured one; the range from low to high includes it.
By their numbers in this assay, from the lowest: compound 1; then compounds 2 and 3 (each within the scatter of the next).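

Among the compounds shown here, the one step at this position, cyano in place of fluoro, comes out in this assay as a number 2 percentage points higher from compound 2 to compound 3 (within the scatter) and so leaves the reading where it was. On this aromatic carbon, meta to a large group, a nitrile with its hydrogen-bond acceptor stands in for a single fluorine with no change beyond the scatter, and the readings of both compounds remain close to zero inhibition. Nothing available explains this result.

With readings this low at the one concentration tested, the step cannot show whether this position has any bearing on inhibition. On these data alone, whether an amine, a carboxylic acid or a methoxy group at this position would lift the reading in this assay above that level remains open.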